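Compound 4 and the Limit Set by Compound 3

A few compounds are considered here, and "the series" means these few. Any claim that something is new, unique, unknown or untested is made for them only; others in the source may bear on it.

In a functional assay on MCF7 cells (Homo sapiens) for inhibition, read by CCK-8 assay, with a stated time of 48 h (on this read-out lower numbers stand for stronger inhibition of growth and higher numbers for weaker inhibition of growth), compound 1 `Cc1ccccc1Nc1nc(Nc2ccc(N3CCN(C)CC3)cn2)ncc1Cl` gives 5210 nM and compound 2 `Cc1ccccc1Nc1nc(Nc2ccc(N3CCNCC3)cn2)ncc1Cl` gives 3410 nM. Compound 3 `COc1ccccc1CNc1nc(Nc2ccc(N3CCN(C)CC3)cn2)ncc1Cl` reports only a limit, > 100000 nM, and not a number.

Compound 4 `CC(C)c1cccc(Nc2nc(Nc3ccc(N4CCN(C)CC4)cn3)ncc2Cl)c1` differs from compound 3 by 3-isopropylphenyl in place of 2-methoxybenzyl on a nitrogen on an aromatic ring, with 3-isopropylphenyl in place of 2-methoxybenzyl on a nitrogen on an aromatic ring. The measured step that bears most directly on this change is the exchange at the same place, 2-methoxybenzyl in place of 2-methylphenyl, which gave an at least 19-fold higher number from compound 1 to compound 3 (1.28 log units; beyond the scatter). Compound 4 returns a phenyl group to that nitrogen, so a large move to a lower number is expected. The step at the other end of the molecule, a 1.5-fold lower number from compound 1 to compound 2 (0.18 log units; within the scatter), concerns a different place and adds little. Going by the values given here, no measured compound carries 3-isopropylphenyl, so the expected range is wide.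

The estimated change is an at least 20-fold lower number from compound 3 to compound 4 (1.30 log units; beyond the scatter). Compound 4 is expected to give about 5000 nM, within an estimated range of 1500 nM to 20000 nM.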

Compound 4, concentration for 50% growth inhibition: 8640 nM
Compound 4: the middle estimate sits 1.7-fold (0.24 log units) below what was measured; the measured number falls inside the stated range.
By their numbers in this assay, from the lowest: compounds 2, 1 and 4 (each within the scatter of the next, the first and the last beyond it). At a limit, above all of these: compound 3.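

Compound 3 stands at a limit and not at a number: the limit of > 100000 nM in this assay, at which 1 of the 4 values shown sits.

In this assay, setting 3-isopropylphenyl in place of 2-methoxybenzyl on this nitrogen gives a large step (an at least 11-fold lower number from compound 3 to compound 4 (1.06 log units; beyond the scatter)), although the two groups carry the same count of heavy atoms, so that count alone does not separate them. The exchange of 2-methylphenyl for 3-isopropylphenyl stays within the scatter (a 1.7-fold higher number from compound 1 to compound 4 (0.22 log units; within the scatter)), so this position carries either substituted phenyl group without a measurable change in growth inhibition.

Since 2-methoxybenzyl differs from both phenyl groups in its methoxy group as well as in its benzyl link, the compounds shown leave open which of the two goes with the loss, a question that plain benzyl and 2-methoxyphenyl would separate. They also leave open how the phenyl ring responds to a hydroxyl group or an amine.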